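This account rests on a few compounds, and the source may have more. Where it says the series, first, only, none or still open, it means among the compounds named here.

Working notes on the series. Compound 1 `CC(/C=N/N(C)c1ccc([N+](=O)[O-])cc1)=N\NC(=O)c1ccc(N)cc1` and compound 2 `CC(/C=N/Nc1ccc([N+](=O)[O-])cc1)=N\NC(=O)c1ccccc1N` share one core and have been tested in an ADME assay on J774 cells (Mus musculus, strain BALB/c) for cytotoxicity, read by resazurin assay, with a stated time of 72 h; a lower number here means that less compound is tolerated, a higher number that more compound is tolerated. Compound 1 gives 51700 nM. Compound 2 gives 29800 nM. Among the compounds with values here, compound 2 and compound 1 differ in more than one place, so no single step between them is counted, and their two values lie within the scatter of each other; on the numbers so far compound 2 sits at the lower of the two, without that gap meaning anything.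

The next step goes from compound 2 to compound 3 `CC(/C=N/Nc1ccc([N+](=O)[O-])cc1)=N\NC(=O)c1ccccc1I`, which is not yet measured in this assay. The difference is iodo in place of amino on an aromatic carbon. Within the data shown here, no measured pair carries the same change, so there is no counted step to lean on; the expectation rests on compound 2 alone and on the size of the change, which replaces one heavy atom by one heavy atom.

For compound 3 a small decrease is expected, close to the scatter rather than clearly beyond it, that is a 1.7-fold lower number from compound 2 to compound 3 (0.22 log units; within the scatter). The estimate for compound 3 in this assay is 18000 nM, with a range from 6000 nM to 50000 nM.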

Compound 3, half-maximal cytotoxic concentration: 40000 nM
For compound 3 the middle estimate is 2.2-fold (0.35 log units) below the measured one, within the range that was stated.
By their numbers in this assay, from the lowest: compounds 2, 3 and 1 (each within the scatter of the next).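

In this assay, within the data shown here, the change of 2-aminophenyl to 2-iodophenyl gives a 1.3-fold higher number from compound 2 to compound 3 (0.13 log units; within the scatter), the first counted step. At this aromatic carbon, ortho to a large group, the exchange of amino for iodo therefore gives no difference that can be read beyond the scatter, even though the hydrogen-bond donor and acceptor counted for amino are absent from iodo, and a nitrogen gives way to an iodine. Among these compounds, this is one pair on one background, so it shows only that these two groups cannot be told apart in this read-out, not that the position is indifferent to substitution in general, and no measurement at hand bears on why the two numbers lie so close.

The compounds shown leave open whether a carboxylic acid, a methoxy group or a longer chain on the same aromatic carbon would give a step beyond the scatter. They also leave open whether amino and iodo would stay within the scatter of each other on the methylated core of compound 1.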